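This account rests on a few compounds, and the source may have more. Where it says the series, first, only, none or still open, it means among the compounds named here.

Measured so far in an assay on CHO cells for displacement of a labelled ligand from adenosine receptor A1 (Homo sapiens), read by scintillation counting, tested at 10 uM; a lower number here means less inhibition, a higher number more inhibition at the concentration tested (going by the name of the read-out):

- Compound 1 `CC(C)(C)Cc1csc(N)c1C(=O)c1cccc(Cl)c1` gives 2%
- Compound 2 `CC(C)(C)Cc1c(-c2ccccn2)sc(N)c1C(=O)c1ccc(Cl)cc1` gives 1%
- Compound 3 `CC(C)(C)Cc1c(Br)sc(N)c1C(=O)c1ccc(Cl)c(Cl)c1` gives 1%

All three compounds share one core, a five-membered aromatic ring with one sulfur that carries an amino group, a neopentyl group and an aryl ketone. In this assay the three numbers lie within the scatter of one another: compound 2 matches compound 3 at the digits shown, and compound 1 differs from compound 2 by only a single percentage point, which is also within the scatter. None of the three shows noticeable displacement of the labelled ligand at the concentration tested.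

Compound 4 `CC(C)(C)Cc1c(-c2ccccc2)sc(N)c1C(=O)c1ccc(Cl)cc1` has not yet been measured. It differs from compound 2 in one place:

phenyl in place of pyridin-2-yl on an aromatic carbon

For the measured compounds named here, no step between two measured compounds that differ in this way is available, so the expectation rests only on the three values at hand. Since compound 2 gives 1% and its two companions sit in the same range, the change is expected to leave the number where it is, with a step from a number 1 percentage points higher from compound 2 to compound 4 (within the scatter) that is not expected to go beyond the scatter. Compound 4 is therefore estimated at 2%, within a range of 0% to 10%.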

Compound 4, a percentage reported as inhibition, at one concentration (the size of the read-out at that concentration, not a potency): 1%
Compound 4: middle estimate off by 1 percentage points, on the high side; the range from low to high includes it.
By their numbers in this assay, from the lowest: compounds 2, 3, 4 and 1 (each within the scatter of the next).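

In this assay, phenyl in place of pyridin-2-yl on the aromatic carbon next to the ring sulfur gives no change at the digits printed from compound 2 to compound 4 (within the scatter). For the compounds shown here, this is the first comparison in which only the group at this position differs, and it shows that the presence or absence of the nitrogen in this six-membered aromatic ring, the one hydrogen-bond acceptor counted in pyridin-2-yl, makes no visible difference to the read-out in this pair. No measurement is available that bears on the reason for this result.

As far as these compounds go, it remains open whether a group of another kind on this carbon, such as an amine or a carboxylic acid, would give a different number. With all the values this low, it is also unknown whether a longer chain in place of the neopentyl group would change the picture.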